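The source may report more compounds than this note shows. Statements on the series, on what has been measured and on what is new or still open speak of the compounds shown alone.

The series rests on a shared core carried by compound 1 `CCN(Cc1ccccc1)C(=O)c1nn(-c2ccc(F)cc2)c(OC[C@@H](O)C[C@@H](O)CC(=O)O)c1C(C)C`, compound 2 `COc1ccccc1CNC(=O)c1nn(-c2ccc(F)cc2)c(OC[C@@H](O)C[C@@H](O)CC(=O)O)c1C(C)C` and compound 3 `COc1cccc(CN(C)C(=O)c2nn(-c3ccc(F)cc3)c(OC[C@@H](O)C[C@@H](O)CC(=O)O)c2C(C)C)c1`. In a functional assay on L6 cells (Rattus norvegicus) for inhibition (a lower number here means a stronger inhibitor, a higher number a weaker inhibitor), compound 1 gives 2660 nM. For compound 2 the same assay reports "not determined" (no result reported), so compound 2 stands on no single number and offers no anchor of its own. The step from compound 2 to compound 3 is a single change: (3-methoxybenzyl)(methyl)amino in place of (2-methoxybenzyl)amino on a carbonyl carbon. Among the compounds with values here, since no measured step is known for this pair, the size and direction of the move in this assay cannot be set from the numbers; the only guide is compound 1, whose value of 2660 nM suggests that this region of the structure tolerates related substitutions without strong gain. Compound 3 is therefore expected to come out near 3000 nM, with a range from 800 nM to 12000 nM reflecting the missing value of compound 2.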

Compound 3, half-maximal inhibitory concentration: 9460 nM
Compound 3: middle estimate off by 3.2-fold (0.50 log units), on the low side, within the range that was stated.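

The exchange of benzyl(ethyl)amino for (3-methoxybenzyl)(methyl)amino on a carbonyl carbon brings in this assay a 3.6-fold higher number from compound 1 to compound 3 (0.55 log units; beyond the scatter), so this position is not indifferent to such a change, and the one measured move here runs toward weaker inhibition. The step from compound 2 to compound 3 cannot be read, and the step that can be read swaps the whole group at once, so it does not separate the effect of the methoxy group from that of the shorter chain on the nitrogen. Nothing at hand accounts for the weaker inhibition.

The compounds shown leave open what the methoxy group contributes by itself and whether the amide hydrogen matters. They also leave open how a group such as morpholine or a fluorobenzyl amine would read in this assay.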